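This account rests on a few compounds, and the source may have more. Where it says the series, first, only, none or still open, it means among the compounds named here.

In a functional assay on cells (Homo sapiens) for antiproliferative activity, read by sulforhodamine B assay, with a stated time of 48 h (a higher number here means a weaker inhibitor, a lower number a stronger inhibitor), compound 1 (`CCCCCCCCCCCCNC(=O)[C@@H]1CSC(c2cc(OC)c(OC)c(OC)c2)N1`) gives 2100 nM, compound 2 (`CCCCCCCCCCCCCCCCNC(=O)[C@@H]1CSC(c2cc(OC)c(OC)c(OC)c2)N1`) gives 1800 nM and compound 3 (`CCCCCCCCCCCCNC(=O)[C@@H]1CSC(c2ccc(OC)c(OC)c2)N1`) gives 2900 nM. These three values all lie within the scatter of one another, so compound 3 stands level with the other two. Compound 4 (`CCCCCCCCCCCCCCCCNC(=O)[C@@H]1CSC(c2ccc(OC)c(OC)c2)N1`) differs from compound 3 by butyl in place of hydrogen on a saturated chain carbon, ten or more bonds along the chain from an amide-type nitrogen, butyl in place of hydrogen on a saturated chain carbon. The same change was measured once, as a 1.2-fold lower number from compound 1 to compound 2 (0.07 log units; within the scatter). The other measured step, a 1.4-fold higher number from compound 1 to compound 3 (0.14 log units; within the scatter), links the two aromatic patterns and is also small. The expected 1.2-fold lower number from compound 3 to compound 4 (0.06 log units; within the scatter) therefore stays within the scatter in this assay. Compound 4 is estimated at 2500 nM, with an expected range of 1400 nM to 4300 nM.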

Compound 4, half-maximal inhibitory concentration: 1500 nM
For compound 4 the middle estimate is 1.7-fold (0.22 log units) above the measured one; low and high end bracket the measured number.
By their numbers in this assay, from the lowest: compounds 4, 2, 1 and 3 (each within the scatter of the next).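

Butyl in place of hydrogen on a saturated chain carbon, now read on the second aromatic pattern, gives a 1.9-fold lower number from compound 3 to compound 4 (0.29 log units; within the scatter) and so stays within the scatter on both cores: the same change on two cores in this assay, a 1.2-fold lower number (0.07 log units; within the scatter) from compound 1 to compound 2 and a 1.9-fold lower number (0.29 log units; within the scatter) from compound 3 to compound 4, 1.7-fold (0.22 log units) apart, within the scatter of two such steps
Hydrogen in place of methoxy on an aromatic carbon, now also read with the longer chain, gives a 1.2-fold lower number from compound 2 to compound 4 (0.08 log units; within the scatter) and so stays within the scatter with both chains: the same change on two cores in this assay, a 1.4-fold higher number (0.14 log units; within the scatter) from compound 1 to compound 3 and a 1.2-fold lower number (0.08 log units; within the scatter) from compound 2 to compound 4, 1.7-fold (0.22 log units) apart, within the scatter of two such steps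
In these four compounds, neither change moves the number beyond the scatter. Still open, as far as these compounds go, is whether a much shorter or longer chain, or an amine or carboxylic acid at the chain end, would do so.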